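A Six-Membered Lactone in Place of a Five-Membered One

A few compounds are considered here, and "the series" means these few. Any claim that something is new, unique, unknown or untested is made for them only; others in the source may bear on it.

Compound 1 `CC/C=C\[C@H](C)[C@H](OC(N)=O)[C@@H](C)[C@H](O)[C@@H](C)C/C(C)=C\[C@H](C)[C@@H](O)[C@@H](C)/C=C\[C@@H](O)C[C@H]1CCC(=O)O1` is the reference point here. In a functional assay on A549 cells (Homo sapiens) for antiproliferative activity (on this read-out higher numbers stand for weaker inhibition of growth and lower numbers for stronger inhibition of growth), compound 1 gives 46 nM, the lower of the two numbers measured, so it is the stronger growth inhibitor of the pair. Compound 2 `CC/C=C\[C@H](C)[C@H](OC(N)=O)[C@@H](C)[C@H](O)[C@@H](C)C/C(C)=C\[C@H](C)[C@@H](O)[C@@H](C)/C=C\[C@@H](O)C[C@@H]1OC(=O)NC[C@H]1C` gives 520 nM in this assay, and the step of an 11-fold higher number from compound 1 to compound 2 (1.05 log units; beyond the scatter) shows what happened when the ring at the chain end was exchanged for a carbamate-containing six-membered ring.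

Compound 3 `CC/C=C\[C@H](C)[C@H](OC(N)=O)[C@@H](C)[C@H](O)[C@@H](C)C/C(C)=C\[C@H](C)[C@@H](O)[C@@H](C)/C=C\[C@@H](O)C[C@@H]1OC(=O)[C@H](C)[C@@H](OC)[C@H]1C` has not yet been measured. It differs from compound 1 as follows: a group of 11 heavy atoms (8 carbon, 3 oxygen; one six-membered non-aromatic ring with 1 hetero atom) in place of a group of 6 heavy atoms (4 carbon, 2 oxygen; one five-membered non-aromatic ring with 1 hetero atom), on a saturated chain carbon, two bonds along the chain from a double-bonded chain carbon and an oxygen on a saturated carbon. The change again replaces the five-membered lactone at the same place, but this time with a six-membered ring carrying only oxygen as its hetero atom, together with added methyl and methoxy groups.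

For the measured compounds named here, only the step from compound 1 to compound 2 bears on this change, and it was large in the weakening direction. Since the entering ring in compound 3 is a different kind of six-membered ring, that step is only a loose guide, and the expectation is a step of a 1.2-fold lower number from compound 1 to compound 3 (0.06 log units; within the scatter), within the scatter. Compound 3 is estimated at 40 nM, within a range of 10 nM to 160 nM.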

Compound 3, concentration for 50% growth inhibition: 6.5 nM
Compound 3: the middle estimate sits 6.2-fold (0.79 log units) above what was measured; measured number below the stated range.
By their numbers in this assay, from the lowest: compound 3; then compound 1; then compound 2.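

In this assay a six-membered ring at this place need not cost growth inhibition, since the new ring gives a 7.1-fold lower number from compound 1 to compound 3 (0.85 log units; beyond the scatter) and so goes the opposite way to the carbamate-containing ring of compound 2. The two six-membered rings also lie far apart, with an 80-fold lower number from compound 2 to compound 3 (1.90 log units; beyond the scatter), so ring size and group size do not settle the outcome here: compound 2 and compound 3 both carry a larger group than compound 1, yet they fall on opposite sides of it. No measurement shown here explains why the ring of compound 3 does better than either of the other two.

Compound 3 differs from compound 2 in several features at once, including the ring hetero atoms and the added methyl and methoxy groups, so the compounds shown cannot say which of these features matters. Going by these compounds, it also remains open how this number would respond to a hydroxyl in place of the methoxy, or to an open-chain carboxylic acid in place of the whole ring.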